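The source may report more compounds than this note shows. Statements on the series, on what has been measured and on what is new or still open speak of the compounds shown alone.

In an ADME assay on microsomes from liver (Mus musculus) for metabolic stability, read by LC-MS, with a stated time of 10 min (on this read-out higher numbers stand for a more stable compound and lower numbers for a less stable compound), compound 1 (`CN(C[C@H]1Cc2c(cccc2N2CCN(C3COC3)CC2)CN1)[C@H]1CCCc2cccnc21`) gives 50.8% and compound 2 (`CN(C[C@@H]1Cc2c(cccc2N2CCNCC2)CN1)[C@H]1CCCc2cccnc21`) gives 54.6% and these two values lie within the usual scatter of each other, so compound 1 does not stand apart from compound 2 on this read-out. Compound 3 (`CN(C[C@H]1Cc2c(cccc2N2CCN(C3CC3)CC2)CN1)[C@H]1CCCc2cccnc21`) has not yet been measured. It keeps the core of compound 1 and differs in one place, with cyclopropyl in place of oxetan-3-yl on an amine nitrogen in a ring. The same difference, cut one bond further out, reads 4-(oxetan-3-yl)piperazin-1-yl to 4-cyclopropylpiperazin-1-yl. For the measured compounds named here, no pair of measured compounds differs in only one place, so the data offer no direct precedent for this exchange, and any forecast remains uncertain. A small downward step is expected, one that may not clearly exceed the scatter. Going by the values given here, the estimated step (a number 5.8 percentage points lower from compound 1 to compound 3 (within the scatter)) starts from the only measured value of the parent. For compound 3 the estimated value is 45% with a wide expected range (29% to 61%).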

Compound 3, percent of the compound remaining: 7%
Compound 3: middle estimate off by 38 percentage points, on the high side; measured number below the stated range.
By their numbers in this assay, from the lowest: compound 3; then compounds 1 and 2 (each within the scatter of the next).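

In this assay, for the compounds shown here, putting cyclopropyl in place of oxetan-3-yl on an amine nitrogen in a ring gives a number 43.8 percentage points lower from compound 1 to compound 3 (beyond the scatter) and so provides the only one-place comparison in this set. It shows that the read-out is sensitive to the group at this position, and that this single exchange, which leaves the core of compound 1 untouched, is enough to produce a large step. No measurement at hand bears on why the exchange has this effect, so the result stands without an explanation.

Going by these compounds, whether the large step is particular to cyclopropyl or would also appear with other groups on this nitrogen, such as methyl, acetyl, cyclobutyl or tetrahydropyran-4-yl, remains open, since a single pair cannot separate these possibilities. On these data alone, it is also open whether the same exchange would produce a step of similar size on the core of compound 2, which differs from compound 1 in its stereochemistry as well as in the group on this nitrogen.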